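Adding a methyl to the pyridinone-bearing acylguanidine

The compounds below may be only part of what the source reports. "The series", "measured", "known", "first", "only" and "open" are said of these compounds alone.

The three compounds measured in a functional assay for inhibition of sodium/hydrogen exchanger (Oryctolagus cuniculus) (on this read-out lower numbers stand for stronger inhibition and higher numbers for weaker inhibition), are:
Compound 1, `CCCCCc1cc(C)c(C(=O)N=C(N)N)cc1S(C)(=O)=O`: 27 nM
Compound 2, `Cc1cc(Sc2ccc(Cl)cc2)c(S(C)(=O)=O)cc1C(=O)N=C(N)N`: 19 nM
Compound 3, `CS(=O)(=O)c1cc(C(=O)N=C(N)N)ccc1-n1ccc(=O)cc1`: 710 nM

Compound 3 gives the highest number of the three, well beyond the scatter from compound 1 and from compound 2. Compound 4, `Cc1cc(-n2ccc(=O)cc2)c(S(C)(=O)=O)cc1C(=O)N=C(N)N`, differs from compound 3 by methyl in place of hydrogen on an aromatic carbon, para to a methylsulfonyl group. Among the compounds with values here, the only measured step, a 1.4-fold lower number from compound 1 to compound 2 (0.15 log units; within the scatter), swaps a different group and so does not bear on this change; no pair of measured compounds differs by this methyl alone. Compound 4 is therefore expected to lie near compound 3, with at most a modest shift, the step of a 1.6-fold lower number from compound 3 to compound 4 (0.20 log units; within the scatter) being the estimate. Compound 4 is estimated at 450 nM, within 150 nM to 1400 nM.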

Compound 4, half-maximal inhibitory concentration: 75 nM
For compound 4 the middle estimate is 6.0-fold (0.78 log units) above the measured one, outside the stated range (below it).
By their numbers in this assay, from the lowest: compounds 2 and 1 (each within the scatter of the next); then compound 4; then compound 3.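

In this assay, methyl in place of hydrogen on an aromatic carbon, para to a methylsulfonyl group, brings a 9.5-fold lower number from compound 3 to compound 4 (0.98 log units; beyond the scatter) and gives the first measure of this change. Even with that methyl present, the group of 7 heavy atoms stays apart from the pentyl and (4-chlorophenyl)sulfanyl groups, with a 3.9-fold higher number from compound 2 to compound 4 (0.60 log units; beyond the scatter) and a 2.8-fold higher number from compound 1 to compound 4 (0.44 log units; beyond the scatter) on those swaps. Nothing available explains why one methyl shifts the number this far. The compounds shown leave open whether an ethyl or a methoxy on this carbon would go further, and whether a chlorine would match the methyl.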